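The source may hold more compounds than are shown below. What is called first, only, known or untested is meant among the compounds shown, and "the series" means these compounds.

In a functional assay on HL-60 cells (Homo sapiens) for antiproliferative activity, read by MTT assay, with a stated time of 48 h (on this read-out lower numbers stand for stronger inhibition and higher numbers for weaker inhibition), compound 1 `C=C1/C=C/C(=O)/C(CO)=C\C[C@](C)(CCC=C(C)C)/C=C/[C@H]1OC(=O)C=C(C)C` gives 2810 nM, while compound 2 `CCN(CC)C/C1=C/C[C@](C)(CCC=C(C)C)/C=C/[C@@H](OC(=O)C=C(C)C)[C@](C)(O)/C=C/C1=O` gives 140 nM, the lower of the two numbers by a margin beyond the scatter. Compound 3 `COCOC/C1=C/C[C@](C)(CCC=C(C)C)/C=C/[C@@H](OC(=O)C=C(C)C)[C@](C)(O)/C=C/C1=O` differs from compound 2 in one place, methoxymethoxy in place of diethylamino on a saturated chain carbon bound to a double-bonded ring carbon. Within the data shown here, no measured step shows the effect of this exchange, so the estimate is loose. In this assay a moderately higher number, beyond the scatter, is expected, with an estimated step of a 3.6-fold higher number from compound 2 to compound 3 (0.55 log units; beyond the scatter). For compound 3 the estimated value is 500 nM, within a range of 150 nM to 1800 nM.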

Compound 3, half-maximal inhibitory concentration: 2840 nM
Compound 3: the middle estimate sits 5.7-fold (0.75 log units) below what was measured, and the stated range ends below it.
By their numbers in this assay, from the lowest: compound 2; then compounds 1 and 3 (each within the scatter of the next).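

In this assay, replacing diethylamino with methoxymethoxy on a saturated chain carbon bound to a double-bonded ring carbon gives a 20-fold higher number from compound 2 to compound 3 (1.31 log units; beyond the scatter) and so marks this place on the shared core as one where the choice of group strongly changes the read-out. Nothing available accounts for the size of this step. Going by these compounds, how a smaller amine such as dimethylamino, a ring amine such as morpholine, or a free hydroxyl would read at this place remains open.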